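Dropping the bromine from compound 1: what to expect

A few compounds are considered here, and "the series" means these few. Any claim that something is new, unique, unknown or untested is made for them only; others in the source may bear on it.

Three related compounds share one core and were tested in a functional assay on C6 cells (Rattus norvegicus) for cytotoxicity, read by MTT assay, with a stated time of 24 h, tested at 100 ug/mL; a lower number here means a stronger effect, a higher number a weaker effect of the compound at the concentration tested. Compound 1 `O=C(CSc1nnnn1-c1ccccc1)N/N=c1/scc(-c2ccc(Br)cc2)n1-c1ccccc1` gives 24.3% in this assay. Compound 2 `Cc1nnc(SCC(=O)N/N=c2/scc(-c3ccc(Cl)cc3)n2-c2ccccc2)s1` gives 34.1% in this assay, a number within the usual scatter of compound 1. Compound 3 `O=C(CSc1ncccn1)N/N=c1/scc(-c2ccc(Br)cc2)n1-c1ccccc1` gives 67.6% in this assay. Among the measured compounds shown here, compound 1 therefore sits at the low end of the three numbers, with compound 2 within the scatter of it and compound 3 well beyond it: the one step known in detail, a number 43.3 percentage points higher from compound 1 to compound 3 (beyond the scatter), shows how much a change at the sulfur can move the read-out.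

Compound 4 `O=C(CSc1nnnn1-c1ccccc1)N/N=c1/scc(-c2ccccc2)n1-c1ccccc1` has not yet been measured. It differs from compound 1 at a different place: hydrogen in place of bromo on an aromatic carbon. For the measured compounds named here, no measured pair of compounds isolates this change; the step from compound 1 to compound 3 concerns the group on the sulfur, and compound 2 differs from compound 1 in two places at once. The change in compound 4 is small, a halogen removed from the outer ring, so a step only modestly beyond the scatter in this assay, if any, is expected, most likely toward a higher number. The estimate for compound 4 is 33%, ranging from 18% to 52%, meaning an expected step of a number 8.7 percentage points higher from compound 1 to compound 4 (within the scatter).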

Compound 4, a percentage reported as activity, at one concentration (the size of the read-out at that concentration, not a potency): 35.8%
Beside the measured number, compound 4's estimate is 2.8 percentage points below it, within the range that was stated.
By their numbers in this assay, from the lowest: compounds 1, 2 and 4 (each within the scatter of the next, the first and the last beyond it); then compound 3.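

In this assay, among the compounds shown here, the change from 4-bromophenyl to phenyl gives a number 11.5 percentage points higher from compound 1 to compound 4 (beyond the scatter) and so shows what no earlier pair could: the group on this aromatic carbon does bear on the read-out, and with hydrogen in place of bromo the effect at the tested concentration is modestly weaker. The step at the sulfur, a number 43.3 percentage points higher from compound 1 to compound 3 (beyond the scatter) by comparison, is much the larger, so among these two single changes to compound 1, replacing the 1-phenyl-1H-tetrazol-5-yl group moves the number far more than removing the bromine does. No measured information here explains why the bromine makes this difference.

The compounds shown leave open whether another group at this place, such as fluoro, methoxy or an amine, would match bromo, fall to the level of hydrogen or go further than either. They also leave open whether removing the bromine from compound 3, which carries the pyrimidin-2-yl group on the sulfur, would shift its number in the same direction and by a similar amount.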